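Swapping the aryl group on a shared core

A few compounds are considered here, and "the series" means these few. Any claim that something is new, unique, unknown or untested is made for them only; others in the source may bear on it.

Compound 1, `Cc1cnc(Nc2ccc(Cl)cc2)nc1Nc1nc2ccccc2s1`: > 50000 nM
Compound 2, `COc1ccc2nc(Nc3nc(Nc4ccc(S(N)(=O)=O)cc4)ncc3F)sc2c1`: > 50000 nM

Of the compounds shown here, two have been measured so far, and neither gave a number. In a functional assay on PC-3 cells (Homo sapiens) for antiproliferative activity, read by MTT assay, with a stated time of 48 h (on this read-out higher numbers stand for weaker inhibition and lower numbers for stronger inhibition), compound 1 gives > 50000 nM, which is a limit of the assay and not a measured value. Compound 2, `COc1ccc2nc(Nc3nc(Nc4ccc(S(N)(=O)=O)cc4)ncc3F)sc2c1`, likewise gives > 50000 nM in this assay, again a limit. Every result so far therefore sits at the limit of > 50000 nM in this assay, at which 2 of the 2 values shown sit. For the measured compounds named here, compound 1 thus stands at the edge of what the assay can report, with no measured compound beneath it to rank it against, and no step between measured compounds exists to show how any change shifts the read-out.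

Compound 3, `COc1cccc(Nc2ncc(C)c(Nc3nc4ccccc4s3)n2)c1`, has not yet been tested. Compared with compound 1 it carries 3-methoxyphenyl in place of 4-chlorophenyl on a nitrogen on an aromatic ring. With compound 1 already at a limit, the step of a number no higher from compound 1 to compound 3 (the limit leaves the size open) is expected to be none beyond the scatter, and compound 3 is expected to return another limit rather than a number. The estimate for compound 3 is 50000 nM, in a range from 10000 nM to 200000 nM.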

Compound 3, half-maximal inhibitory concentration: > 50000 nM
Compound 3: a limit, no number (the forecaster's own chance of this, stated with the estimate: 75%); the middle value lies on the limit itself.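

Compound 1 and compound 3 both returned a limit of the assay rather than a number, so no step can be read for the change from 4-chlorophenyl to 3-methoxyphenyl. The compounds shown leave open whether any aryl group on the shared core can give a measurable value in this assay.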